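The source may report more compounds than this note shows. Statements on the series, on what has been measured and on what is new or still open speak of the compounds shown alone.

Compound 1 `Cc1cc(C)nc(NS(=O)(=O)c2ccc(Nc3nncc4ccccc34)cc2)n1`: 3.4 nM
Compound 2 `O=S(=O)(Nc1ccccn1)c1ccc(Nc2nncc3ccccc23)cc1`: 36 nM
Compound 3 `Cc1cc(NS(=O)(=O)c2ccc(Nc3nncc4ccccc34)cc2)no1`: 27 nM

In a functional assay on MDA-MB-435 cells (Homo sapiens) for antiproliferative activity, read by sulforhodamine B assay, with a stated time of 72 h (a lower number here means a stronger inhibitor, a higher number a weaker inhibitor), compound 3 sits level with compound 2, the step being a 1.3-fold lower number from compound 2 to compound 3 (0.12 log units; within the scatter). Compound 1 stands apart, with a 7.9-fold higher number from compound 1 to compound 3 (0.90 log units; beyond the scatter). Compound 4 `NS(=O)(=O)c1ccc(Nc2nncc3ccccc23)cc1` differs from compound 3 by one change: hydrogen in place of 5-methyl-1,2-oxazol-3-yl on a sulfonamide nitrogen. That is hydrogen in place of 5-methyl-1,2-oxazol-3-yl on a sulfonamide nitrogen. Going by the values given here, no measured step removes the group outright. The nearest evidence is exchanges of one group for another on that nitrogen, and these reach an 11-fold higher number from compound 1 to compound 2 (1.02 log units; beyond the scatter). All three measured compounds carry a group there, so a modest move to a higher number is expected, with real uncertainty about its direction. The expected step is a 1.9-fold higher number from compound 3 to compound 4 (0.27 log units; within the scatter). For compound 4 the estimate is 50 nM, with an expected range of 9 nM to 300 nM.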

Compound 4, half-maximal inhibitory concentration: 18 nM
The estimate for compound 4 lay 2.8-fold (0.44 log units) above the measured number; the measured number falls inside the stated range.
By their numbers in this assay, from the lowest: compound 1; then compounds 4, 3 and 2 (each within the scatter of the next).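

In this assay, compound 4 shows that the group on the sulfonamide nitrogen can be replaced by hydrogen with no step beyond the scatter from the 5-methyl-1,2-oxazol-3-yl group (a 1.5-fold lower number from compound 3 to compound 4 (0.18 log units; within the scatter)) or the pyridin-2-yl group (a 2.0-fold lower number from compound 2 to compound 4 (0.30 log units; within the scatter)). Only the 4,6-dimethylpyrimidin-2-yl group stands apart from hydrogen (a 5.3-fold higher number from compound 1 to compound 4 (0.72 log units; beyond the scatter)). Nothing measured here bears on why. The compounds shown leave open whether a pyrimidin-2-yl group without the two methyl groups would keep the lower number of compound 1, and how an acetyl group on that nitrogen would compare.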